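Chloro on the anilino ring of compound 2

A few compounds are considered here, and "the series" means these few. Any claim that something is new, unique, unknown or untested is made for them only; others in the source may bear on it.

Compound 1 `CCCCNC(=O)c1c(NC(=O)NS(=O)(=O)c2ccccc2)sc2c1CCCCC2` gives 92600 nM in a functional assay on cells (Cancer cell lines, Homo sapiens) for inhibition, with a stated time of 48 h; on this read-out higher numbers stand for weaker inhibition of growth and lower numbers for stronger inhibition of growth. Compound 2 `O=C(Nc1sc2c(c1C(=O)NNc1ccccc1)CCCCC2)NS(=O)(=O)c1ccccc1` is only reported at the limit of the assay, > 100000 nM, so no number exists for it. The step of an at least 1.0-fold higher number from compound 1 to compound 2 (0.03 log units; that floor lies within the scatter) is therefore only a floor, and it lies within the scatter; the limit itself is recorded at the limit of > 100000 nM in this assay, at which 1 of the 2 values shown sits.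

Compound 3 `O=C(Nc1sc2c(c1C(=O)NNc1ccc(Cl)cc1)CCCCC2)NS(=O)(=O)c1ccccc1` differs from compound 2 by the change (chloro in place of hydrogen on an aromatic carbon), that is chloro in place of hydrogen on an aromatic carbon of a six-membered aromatic ring of carbon only, para to a large group. Within the data shown here, no measured step concerns a chloro entering or leaving, so nothing among the measured pairs bears directly on this change. Among the measured compounds shown here, the only measured step, from butyl to anilino, stayed within the scatter and ended at the limit. On this basis no shift beyond the scatter is expected for compound 3 in this assay; the step of a number no higher from compound 2 to compound 3 (the limit leaves the size open) is an estimate of no real movement. Compound 3 is expected to sit near 100000 nM, between 30000 nM and 300000 nM, most likely again as a limit rather than a number.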

Compound 3, concentration for 50% growth inhibition: 14500 nM
For compound 3 the middle estimate is 6.9-fold (0.84 log units) above the measured one, outside the stated range (below it).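

Chloro in place of hydrogen on an aromatic carbon, para to a large group, is the first change in the series to give a step beyond the scatter in this assay, with an at least 6.8-fold lower number from compound 2 to compound 3 (0.83 log units; beyond the scatter). Compound 2 stands only as a limit, so that step is a floor and its full size cannot be read: the limit of > 100000 nM in this assay, at which 1 of the 3 values shown sits. The comparison with the butyl amide gives a 6.4-fold lower number from compound 1 to compound 3 (0.81 log units; beyond the scatter), and with both steps printed beyond the scatter, compound 3 is the most potent of the three compounds shown in this assay.

With chloro the only substituent shown on this ring, it remains open whether the shift belongs to chloro itself or would also follow from fluoro, bromo, methyl or methoxy on the same carbon. Also open is whether a trifluoromethyl or a second chloro on this ring would take compound 3, at 14500 nM, lower still, and the compounds shown give no measured property that would explain the movement.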